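This account rests on a few compounds, and the source may have more. Where it says the series, first, only, none or still open, it means among the compounds named here.

Of the compounds shown here, three of the shared core have been measured in a functional assay on MCF7 cells (Homo sapiens) for antiproliferative activity, with a stated time of 48 h; a higher number here means a weaker inhibitor, a lower number a stronger inhibitor. Compound 1 `CC(C)(C)c1ccc(CNC(=O)NCCCCl)cc1` gives 17000 nM; compound 2 `CC(C)(C)c1ccc(CNC(=O)CCCl)cc1` gives 67000 nM; compound 3 `CC(C)(C)c1ccc(CNC(=O)CCCCl)cc1` gives 92000 nM. Compound 3 stands at the highest of the three numbers: one step is a 1.4-fold higher number from compound 2 to compound 3 (0.14 log units; within the scatter), which lies within the scatter, and another is a 5.4-fold higher number from compound 1 to compound 3 (0.73 log units; beyond the scatter), which lies beyond it. The step of a 3.9-fold higher number from compound 1 to compound 2 (0.60 log units; beyond the scatter) is of similar size.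

Compound 4 `C=CC(=O)NCc1ccc(C(C)(C)C)cc1` is the next member. It differs from compound 3 by vinyl in place of 3-chloropropyl on a carbonyl carbon. Among the measured compounds shown here, no measured step covers this change; the steps from compound 1 to compound 2 and from compound 1 to compound 3 show that exchanging the group on the carbonyl carbon has moved this assay only modestly, and the step from compound 2 to compound 3 shows that shortening the chain stayed within the scatter. On that basis a modest move in this assay is expected, with no direction that the measured steps can fix, so the estimate is set near the middle of the measured span with a wide range: for compound 4 the expected value is 40000 nM, between 6000 nM and 250000 nM, meaning an expected step of a 2.3-fold lower number from compound 3 to compound 4 (0.36 log units; beyond the scatter).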

Compound 4, half-maximal inhibitory concentration: > 100000 nM
Compound 4: no number, only a limit; the forecaster's own chance of this, stated with the estimate: 20%; middle value at least 2.5-fold (0.39 log units) from the limit.
By their numbers in this assay, from the lowest: compound 1; then compounds 2 and 3 (each within the scatter of the next). At a limit, above all of these: compound 4.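

Compound 4 in this assay gives no number, only a floor for vinyl on the carbonyl carbon: the limit of > 100000 nM in this assay, at which 1 of the 4 values shown sits. Against the chlorinated chains the floors are an at least 1.0-fold higher number from compound 3 to compound 4 (0.03 log units; that floor lies within the scatter) and an at least 1.4-fold higher number from compound 2 to compound 4 (0.17 log units; that floor lies within the scatter), so vinyl in place of 3-chloropropyl or 2-chloroethyl brings no lower number in this assay, and any rise cannot be sized from these floors. Among the compounds shown here, the one floor beyond the scatter is an at least 5.8-fold higher number from compound 1 to compound 4 (0.76 log units; beyond the scatter), which keeps compound 1 at the lowest number of the four and shows for the first time that a group without chlorine at this position does not approach it.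

Still open, on these data alone, is how far beyond its limit compound 4 lies, and whether the gap to compound 1 follows the nitrogen or the chlorine of (3-chloropropyl)amino. A plain propylamino group, a 4-chlorobutyl chain or a saturated ethyl group on the same carbonyl carbon would separate those readings, and would show whether the double bond of vinyl or the loss of chlorine matters in this series.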